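Adding a Hydroxy Group to the Sugar Ring of Compound 2

The source may report more compounds than this note shows. Statements on the series, on what has been measured and on what is new or still open speak of the compounds shown alone.

Compound 1 `COc1ccc2c(c1)COP(=O)(OC[C@@H]1C=C[C@H](n3cnc4c(N)ncnc43)O1)O2`: 14.5 h
Compound 2 `Cc1cccc2c1OP(=O)(OCC1CCC(n3cnc4c(O)ncnc43)O1)OC2`: 44.5 h

In an ADME assay for metabolic stability, in phosphate buffer, at pH 7.3 (a higher number here means that the compound lasts longer, a lower number that the compound disappears faster), compound 2 gives the higher of the two numbers; compound 1 gives 14.5 h, which is beyond the usual scatter. Compound 3 `Cc1cccc2c1OP(=O)(OCC1CC(O)C(n3cnc4c(O)ncnc43)O1)OC2` is not yet measured. It differs from compound 2 by hydroxy in place of hydrogen on a saturated ring carbon. Going by the values given here, no pair of measured compounds shows what this change does, so a step of no more than the scatter is expected in either direction. For compound 3 the value in this assay is estimated at 40 h, ranging from 20 h to 80 h, an expected step of a 1.1-fold lower number from compound 2 to compound 3 (0.05 log units; within the scatter).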

Compound 3, half-life in the ADME assay: 29.7 h
For compound 3 the middle estimate is 1.3-fold (0.13 log units) above the measured one, within the range that was stated.
By their numbers in the ADME assay, from the lowest: compound 1; then compounds 3 and 2 (each within the scatter of the next).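

In the ADME assay this position takes hydroxy in place of hydrogen with a 1.5-fold lower number from compound 2 to compound 3 (0.18 log units; within the scatter) and so without a clear shift. In a physicochemical assay for lipophilicity (a lower number here means a more polar compound, a higher number a more lipophilic compound), compound 2 gives 0.14 and compound 3 gives 0.078 so the two numbers also lie within the scatter of each other, even with a hydroxy group added to the ring. Nothing available gives a reason for either result. The compounds shown leave open whether an amine, a methoxy group or a fluorine atom on this same saturated ring carbon would give a step beyond the scatter.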